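Benzylsulfanyl substitution on the shared core: compound 4

The compounds below may be only part of what the source reports. "The series", "measured", "known", "first", "only" and "open" are said of these compounds alone.

Measured so far in a functional assay on MGC-803 cells (Homo sapiens) for inhibition, read by MTT assay, with a stated time of 72 h; on this read-out lower numbers stand for stronger inhibition and higher numbers for weaker inhibition:
compound 1 `Cc1cc(Nc2cc(-c3ccccc3)[nH]n2)n2ncnc2n1` gives 21700 nM
compound 2 `Cc1cc(Nc2cc(-c3ccccc3)[nH]n2)n2nc(SCc3ccc(Cl)cc3)nc2n1` gives 3950 nM
compound 3 `Cc1cc(Nc2cc(-c3ccccc3)[nH]n2)n2nc(SCc3cccc4ccccc34)nc2n1` gives 3120 nM

Compound 1 shows the highest number of the three in this assay. The step of a 5.5-fold lower number from compound 1 to compound 2 (0.74 log units; beyond the scatter) bears directly on compound 4 `Cc1cc(Nc2cc(-c3ccccc3)[nH]n2)n2nc(SCc3ccc(Br)cc3)nc2n1`, whose change from compound 1 is (4-bromobenzyl)sulfanyl in place of hydrogen on an aromatic carbon. The further step a 1.3-fold lower number from compound 2 to compound 3 (0.10 log units; within the scatter) indicates that exchanging the aryl group on the same chain moves the number little. For compound 4 a downward step in this assay of about the size seen for compound 2 is therefore expected, a 5.7-fold lower number from compound 1 to compound 4 (0.76 log units; beyond the scatter). Compound 4 is estimated at 3800 nM, with a range from 1900 nM to 7600 nM.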

Compound 4, half-maximal inhibitory concentration: 1110 nM
Beside the measured number, compound 4's estimate is 3.4-fold (0.53 log units) above it; measured number outside the range, below it.
By their numbers in this assay, from the lowest: compound 4; then compounds 3 and 2 (each within the scatter of the next); then compound 1.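

In this assay the full change on this aromatic carbon reaches a 20-fold lower number from compound 1 to compound 4 (1.29 log units; beyond the scatter) and so goes well past what the chlorinated benzyl group had shown. The para-free reading is simple: the halogen on the benzyl ring counts, with a 3.6-fold lower number from compound 2 to compound 4 (0.55 log units; beyond the scatter) for bromo in place of chloro, and the aryl group on the chain is no longer shown as interchangeable, with a 2.8-fold lower number from compound 3 to compound 4 (0.45 log units; beyond the scatter) for 4-bromophenyl in place of naphthalen-1-yl. No measurement shown here accounts for the difference between bromo and chloro.

Going by these compounds, whether iodo or methoxy on the benzyl ring would follow bromo remains open. So does the effect of a longer chain between the sulfur and the ring, or of an amine on that ring.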